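The compounds below may be only part of what the source reports. "The series", "measured", "known", "first", "only" and "open" are said of these compounds alone.

The measured compounds:

compound 1, `CCN(CC)c1ccc(C(F)(F)F)cc1NC(=O)c1cccnc1`, 71000 nM;
compound 2, `CCN(CC)c1ccc(C(F)(F)F)cc1NC(=O)c1ccncc1`, 89700 nM.

Both numbers come from a functional assay on HL-60 cells (Homo sapiens) for cytotoxicity, read by MTT assay, with a stated time of 48 h; a higher number here means a weaker inhibitor, a lower number a stronger inhibitor. Compound 2 and compound 1 lie within the usual scatter of each other: the step of a 1.3-fold higher number from compound 1 to compound 2 (0.10 log units; within the scatter) is too small to be read as a real change, so compound 2 does not stand apart from compound 1, and both are weak in this assay.

Compound 3, `CCN(CC)c1ccc(C(F)(F)F)cc1NC(=O)c1ccccc1`, has not been measured. It differs from compound 2 in one place: phenyl in place of pyridin-4-yl on a carbonyl carbon. Within the data shown here, only one measured step touches the same ring, the step of a 1.3-fold higher number from compound 1 to compound 2 (0.10 log units; within the scatter), which moved the ring nitrogen without a change beyond the scatter. Among the measured compounds shown here, no measured step removes that nitrogen altogether, so the data give no direct reading for the change to phenyl. On that basis compound 3 is expected to show at most a small step in this assay, with no direction that the data support, as a step of a 1.1-fold lower number from compound 2 to compound 3 (0.05 log units; within the scatter). The estimate for compound 3 in this assay is 80000 nM, with a range from 30000 nM to 200000 nM.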

Compound 3, half-maximal inhibitory concentration: "not active" (no number reported)
The entry for compound 3 holds no number; no gap can be computed for the estimate.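

In this assay, among these compounds, compound 3 is recorded as "not active" with no number, so no step from compound 2 to compound 3 can be read. Nothing available bears on this result. The compounds shown leave open how far phenyl in compound 3 separates it from pyridin-4-yl in compound 2.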